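The compounds below may be only part of what the source reports. "The series", "measured", "known", "first", "only" and "open" are said of these compounds alone.

Measured compounds:
compound 1 `Brc1cccc(Cn2ccc3nc(-c4ccccc4)nc-3c2)c1` gives 85000 nM
compound 2 `FC(F)(F)c1cccc(Cn2ccc3nc(-c4ccccc4)nc-3c2)c1` gives 98000 nM
compound 3 `c1ccc(CCCCn2ccc3nc(-c4ccccc4)nc-3c2)cc1` gives 95000 nM

The three measured compounds share one core and differ only in the group carried on the saturated chain carbon bound to an aromatic nitrogen. In an ADME assay on MDBK cells (Bos taurus) for cytotoxicity (a lower number here means that less compound is tolerated, a higher number that more compound is tolerated), compound 1 gives 85000 nM, the lowest of the three numbers, but its distance to compound 3 and to compound 2 lies within the scatter, so the three values cannot be told apart. Among the compounds with values here, the one step available, a 1.2-fold higher number from compound 1 to compound 2 (0.06 log units; within the scatter), shows that exchanging one aromatic substituent for another left the read-out where it was.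

Compound 4 `c1ccc(-c2nc3ccn(Cc4ccncc4)cc-3n2)cc1` is not yet measured. It differs from compound 1 as follows: pyridin-4-yl in place of 3-bromophenyl on a saturated chain carbon bound to an aromatic nitrogen. Within the data shown here, no measured step covers this exchange of a whole aromatic ring for a six-membered aromatic ring with one hetero atom, so the expectation rests on the measured values alone, which sit within the scatter of one another for three different groups at this place. Compound 4 is therefore expected to give 90000 nM in this assay, in the range 45000 nM to 180000 nM, meaning an estimated step of a 1.1-fold higher number from compound 1 to compound 4 (0.02 log units; within the scatter) that does not go beyond the scatter.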

Compound 4, half-maximal cytotoxic concentration: > 100000 nM
Compound 4 ended at the assay's limit (the forecaster's own chance of this, stated with the estimate: 30%); middle value at least 1.1-fold (0.04 log units) from the limit.
By their numbers in this assay, from the lowest: compounds 1, 3 and 2 (each within the scatter of the next). At a limit, above all of these: compound 4.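

Compound 4 gives > 100000 nM in this assay, and this value is a limit of the assay, not a number. Compound 4 is the only compound shown with a hetero atom in the aromatic ring on a saturated chain carbon bound to an aromatic nitrogen, so it shows that pyridin-4-yl, with its hydrogen-bond acceptor, can replace 3-bromophenyl at this place without bringing the number down, the step being an at least 1.1-fold higher number from compound 1 to compound 4 (0.07 log units; that floor lies within the scatter). That floor does not establish a real rise, and the true size of the step stays unknown, since the read-out of compound 4 ends where the assay ends: the limit of > 100000 nM in this assay, at which 1 of the 4 values shown sits.

The compounds shown leave open how far beyond the limit compound 4 lies, and whether pyridin-3-yl or pyridin-2-yl would behave as pyridin-4-yl does. They also leave open whether an amine or a carboxylic acid on the aromatic ring at this place, or a longer chain ending in pyridin-4-yl, would keep the read-out at the limit or bring it back into the measurable range.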